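A few compounds are considered here, and "the series" means these few. Any claim that something is new, unique, unknown or untested is made for them only; others in the source may bear on it.

Compound 1 `C=C(Br)C(=O)Nc1ccc2c(c1)/C(=C/c1cccs1)C(=O)N2` gives 12 nM 
Compound 2 `C=C(Br)C(=O)Nc1ccc2c(c1)/C(=C\c1cccs1)C(=O)N2` gives 530 nM 
Compound 3 `C=C(Br)C(=O)Nc1ccc2c(c1)CC(=O)N2` gives 220 nM 

These numbers come from a functional assay on RS4-11 cells (Homo sapiens) for antiproliferative activity, read by MTT assay, with a stated time of 72 h (a lower number here means a stronger inhibitor, a higher number a weaker inhibitor), and compound 1 has the lowest of the three. Compound 4 `C=C(Br)C(=O)Nc1ccc2c(c1)/C(=C/c1ccc(C)s1)C(=O)N2` is the next to be tested, and it differs from compound 1 in one place. The thiophen-2-yl group becomes 5-methylthiophen-2-yl, and methyl in place of hydrogen on an aromatic carbon gives the full count of that change.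

Among the compounds with values here, the only measured step is a 44-fold higher number from compound 1 to compound 2 (1.65 log units; beyond the scatter) and it is large. Behind it stands the fact that compounds 1 and 2 differ only in the configuration as drawn and not any added group. That step shows that numbers in this small set can move a long way, but it does not carry over directly. Within the data shown here, compound 4 keeps the double bond drawn as in compound 1, and no measured compound carries a group on the sulfur-containing ring. The size of a methyl effect there therefore remains unmeasured, and a modest step is the cautious expectation. The expected step is a 1.5-fold higher number from compound 1 to compound 4 (0.18 log units; within the scatter) and this means no clear change beyond the scatter, with a slight lean towards a higher number. Compound 4 is estimated at 18 nM with an expected range from 5 nM to 60 nM as the likely span.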

Compound 4, half-maximal inhibitory concentration: 450 nM
For compound 4 the middle estimate is 25-fold (1.40 log units) below the measured one; measured number above the stated range.
By their numbers in this assay, from the lowest: compound 1; then compound 3; then compounds 4 and 2 (each within the scatter of the next).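

This position proves far less forgiving than a change of this size might suggest: in this assay, going from thiophen-2-yl to 5-methylthiophen-2-yl adds a single carbon and gives a 38-fold higher number from compound 1 to compound 4 (1.57 log units; beyond the scatter). The carbon next to the ring sulfur, two ring bonds from the ring atom that bears a large group, therefore matters for activity in these cells, and even a methyl there is enough to produce a large step. The step is of a similar size to a 44-fold higher number from compound 1 to compound 2 (1.65 log units; beyond the scatter), yet compound 4 keeps the double bond as drawn in compound 1, so two quite different changes each produce a large step, and the earlier one was of another kind: the fact that compounds 1 and 2 differ only in the configuration as drawn.

The compounds shown leave open whether any group on this carbon brings such a step or whether it belongs to methyl alone, and a fluorine, a chlorine, a methoxy group or a hydroxymethyl group would help to separate these two readings. They also leave open whether a methyl on another carbon of the same ring would give a step of this size.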